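The source may report more compounds than this note shows. Statements on the series, on what has been measured and on what is new or still open speak of the compounds shown alone.

Of the compounds shown here, three built on closely related cores have been measured in an assay on cell membranes for displacement of a labelled ligand from corticotropin-releasing factor receptor 1 (Rattus norvegicus); a lower number here means a stronger inhibitor, a higher number a weaker inhibitor. Compound 1 `CCC(CC)Nc1nc(C)nc2c(-c3ccc(OC)nc3C)c(C)nn12` gives 3.1 nM. Compound 3 `CCN(CC)c1nc(C)nc2c(-c3ccc(OC)nc3C)c(C)nn12` gives 12 nM; the two share one core and differ by (pentan-3-yl)amino in place of diethylamino on an aromatic carbon, a step of a 3.9-fold lower number from compound 3 to compound 1 (0.59 log units; beyond the scatter). Compound 2 `CCN(CC)c1nc(C)nc2c(-c3cnc(OC)cc3C)c(C)nn12` gives 14.5 nM; its core and that of compound 3 hold the same atoms joined differently, and the difference between the two cores is not broken down here. Compound 4 `CCC(CC)Nc1nc(C)nc2c(-c3cnc(OC)cc3C)c(C)nn12` is not yet measured; it differs from compound 2 by (pentan-3-yl)amino in place of diethylamino on an aromatic carbon, the same kind of change seen from compound 3 to compound 1. In this assay the expected step from compound 2 to compound 4 is a 3.9-fold lower number from compound 2 to compound 4 (0.59 log units; beyond the scatter), resting on the step of a 3.9-fold lower number from compound 3 to compound 1 (0.59 log units; beyond the scatter). Compound 4 is therefore expected to give about 3.7 nM, between 1.5 nM and 9 nM.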

Compound 4, half-maximal inhibitory concentration: 3 nM
The estimate for compound 4 lay 1.2-fold (0.09 log units) above the measured number, within the range that was stated.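

In this assay, (pentan-3-yl)amino in place of diethylamino gives a 4.8-fold lower number from compound 2 to compound 4 (0.68 log units; beyond the scatter), and the change carries over between the two cores with much the same size: the same change on two cores in this assay, a 3.9-fold lower number (0.59 log units; beyond the scatter) from compound 3 to compound 1 and a 4.8-fold lower number (0.68 log units; beyond the scatter) from compound 2 to compound 4, 1.2-fold (0.10 log units) apart, within the scatter of two such steps. For these two closely related cores, then, the size of the step did not depend on which core carried it. Two pairs do not show that this holds on a more different core, and they do not explain why the number falls.

The entering group also differs from the leaving one in having a hydrogen-bond donor, and these compounds cannot separate that difference from the change in the chain. On these data alone, how a methyl(pentan-3-yl)amino group or a morpholine ring would behave at this place remains open.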